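From Isopropoxy to Butoxy on a Shared Core

This account rests on a few compounds, and the source may have more. Where it says the series, first, only, none or still open, it means among the compounds named here.

Among the measured compounds shown here, in a functional assay on corpus cavernosum (Rattus norvegicus) for activation (on this read-out higher numbers stand for an effect only at larger amounts of compound and lower numbers for an effect already at smaller amounts), compound 1 `CCCOc1ccccc1-c1nc2c(cnn2-c2ccccc2)c(=O)[nH]1` gives 234 nM and compound 2 `CC(C)Oc1ccccc1-c1nc2c(cnn2-c2ccccc2)c(=O)[nH]1` gives 500 nM, the higher of the two numbers so far. Compound 3 `CCCCOc1ccccc1-c1nc2c(cnn2-c2ccccc2)c(=O)[nH]1` shares their core but has not yet been measured. Its difference from compound 2 is butyl in place of isopropyl on an oxygen on an aromatic ring. For the measured compounds named here, only one measured step bears on this change, the modest 2.1-fold higher number from compound 1 to compound 2 (0.33 log units; beyond the scatter), which goes with isopropyl in place of propyl. Going by the values given here, no butyl compound has a measured value, so the expectation rests on the assumption that butyl will resemble the propyl of compound 1 at 234 nM. In this assay, a step of similar size toward a lower number is therefore expected, estimated as a 2.3-fold lower number from compound 2 to compound 3 (0.36 log units; beyond the scatter). For compound 3 the estimated value is 220 nM, with an expected range from 80 nM to 600 nM.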

Compound 3, half-maximal effective concentration: 630 nM
Compound 3: the middle estimate sits 2.9-fold (0.46 log units) below what was measured; the whole stated range lies below it.
By their numbers in this assay, from the lowest: compound 1; then compounds 2 and 3 (each within the scatter of the next).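

In this assay, butyl and isopropyl on this oxygen cannot be told apart, with a 1.3-fold higher number from compound 2 to compound 3 (0.10 log units; within the scatter). Lengthening the straight chain of compound 1 by one methyl gives a 2.7-fold higher number from compound 1 to compound 3 (0.43 log units; beyond the scatter), so the lower number of compound 1 does not carry over to the longer straight chain, and among these three compounds propyl alone stands apart, with the steps to both isopropyl and butyl beyond the scatter. No supporting evidence is available to explain why this position responds in this way.

Whether propyl marks a true optimum remains open, since the compounds shown stop at propyl, isopropyl and butyl and leave the effect of a shorter ethyl or a longer pentyl on this oxygen unknown. Going by these compounds, what an amine or a carboxylic acid at the end of the chain would do here also remains open.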